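Predicting Tolerance of Compound 4 from Three Analogues

The compounds below may be only part of what the source reports. "The series", "measured", "known", "first", "only" and "open" are said of these compounds alone.

The series shares one core and differs only in the aryl group on an oxygen on a saturated carbon. In an ADME assay on Vero cells (Chlorocebus sabaeus) for cytotoxicity, read by luminescence, with a stated time of 2 days (a higher number here means that more compound is tolerated, a lower number that less compound is tolerated), compound 1 `CCc1nc2ccccc2n1CCCCOc1ccccc1` gives 21 uM. Compound 2 `CCc1nc2ccccc2n1CCCCOc1ccc(C)cc1` gives 14 uM in this assay, the second highest of the three numbers: the step of a 1.5-fold lower number from compound 1 to compound 2 (0.18 log units; within the scatter) lies within the scatter, whereas compound 3 `CCc1nc2ccccc2n1CCCCOc1ccc(Cl)cc1F`, with 5.7 uM in this assay, sits lower by a 2.5-fold lower number from compound 2 to compound 3 (0.39 log units; beyond the scatter).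

Compound 4 `CCc1nc2ccccc2n1CCCCOc1ccc(Cl)cc1C` is not yet measured. It differs from compound 2 by 4-chloro-2-methylphenyl in place of 4-methylphenyl on an oxygen on a saturated carbon. For the measured compounds named here, two measured steps bear on this change. The closest is a 2.5-fold lower number from compound 2 to compound 3 (0.39 log units; beyond the scatter), where a 4-chloro-2-fluorophenyl replaced the same 4-methylphenyl; the other is a 3.7-fold lower number from compound 1 to compound 3 (0.57 log units; beyond the scatter). Both introduce a chlorine and both lowered the number beyond the scatter, while a 1.5-fold lower number from compound 1 to compound 2 (0.18 log units; within the scatter) shows that a methyl alone made no difference beyond the scatter. Compound 4 carries the chlorine of compound 3 together with a methyl where compound 3 has a fluorine, so a modest drop comparable to that seen for compound 3 is expected, a 2.0-fold lower number from compound 2 to compound 4 (0.30 log units; within the scatter). The estimate for compound 4 in this assay is therefore 7 uM, with a range from 3.5 uM to 14 uM.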

Compound 4, half-maximal toxic concentration: 20 uM
Compound 4: middle estimate off by 2.9-fold (0.46 log units), on the low side; measured number outside the range, above it.
By their numbers in this assay, from the lowest: compound 3; then compounds 2, 4 and 1 (each within the scatter of the next).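

In this assay, the presence of a chlorine on the aryl group does not by itself go with a lower number: with 4-chloro-2-methylphenyl on the oxygen, the reading shows a 1.4-fold higher number from compound 2 to compound 4 (0.15 log units; within the scatter) and a 1.1-fold lower number from compound 1 to compound 4 (0.02 log units; within the scatter), so phenyl, 4-methylphenyl and 4-chloro-2-methylphenyl cannot be told apart here. The only new step beyond the scatter is methyl in place of fluoro on an aromatic carbon, with a 3.5-fold higher number from compound 3 to compound 4 (0.55 log units; beyond the scatter), so among these four compounds the lower number belongs to compound 3 alone, and compound 4 goes against any link between chlorine and a lower number. No measurement at hand accounts for this gap between the fluoro and methyl compounds.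

On these data alone, it remains open what a plain 4-chlorophenyl or a plain 2-methylphenyl on the oxygen would give, and so whether the reading of compound 4 depends on its chlorine, its methyl or the two together. Also open, as far as these compounds go, is how this assay would respond to an amine or a carboxylic acid on the aryl group, or to a longer chain linking the oxygen to the shared core.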